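The compounds below may be only part of what the source reports. "The series", "measured", "known", "first", "only" and "open" are said of these compounds alone.

Values measured so far in a functional assay on HepG2 cells (Homo sapiens) for antiproliferative activity, read by MTT assay, with a stated time of 24 h; on this read-out lower numbers stand for stronger inhibition and higher numbers for weaker inhibition:

- compound 1 `COc1cc(OC)c(-c2coc3cc(OCC=C(C)C)ccc3c2=O)cc1OC`: 280 nM
- compound 2 `C#CCOc1ccc2c(=O)c(-c3cc(OC)c(OC)cc3OC)coc2c1`: 4950 nM
- compound 3 `COc1cc(OC)c(-c2coc3cc(OCc4ccc(F)cc4)ccc3c2=O)cc1OC`: 1000 nM

Compound 3, at 1000 nM, holds the middle place of the three numbers. Compound 1 gives the lowest number and compound 2 the highest, each beyond the scatter from compound 3.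

Compound 4 `COc1cc(OC)c(-c2coc3cc(OCc4ccccc4C)ccc3c2=O)cc1OC` keeps the shared core and differs from compound 3 only on the saturated chain carbon bound to an oxygen on an aromatic ring, with 2-methylphenyl in place of 4-fluorophenyl on a saturated chain carbon bound to an oxygen on an aromatic ring.

All three measured steps fall at this same place, but none exchanges one phenyl group for another, so they give no direction for this change. The largest is an 18-fold higher number from compound 1 to compound 2 (1.25 log units; beyond the scatter), and it involves no phenyl group. The two that reach compound 3 are smaller, at a 3.6-fold higher number from compound 1 to compound 3 (0.55 log units; beyond the scatter) and a 5.0-fold lower number from compound 2 to compound 3 (0.69 log units; beyond the scatter), and each exchanges the 4-fluorophenyl for a group without a ring. Here the ring count stays the same, so a smaller change is expected in this assay, with no clear direction.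

The expected step is a 1.1-fold lower number from compound 3 to compound 4 (0.05 log units; within the scatter), and no shift beyond the scatter is anticipated. For compound 4 the estimated value is 900 nM, with an expected range from 300 nM to 2700 nM.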

Compound 4, half-maximal inhibitory concentration: 1860 nM
Beside the measured number, compound 4's estimate is 2.1-fold (0.32 log units) below it; the measured number falls inside the stated range.
By their numbers in this assay, from the lowest: compound 1; then compounds 3 and 4 (each within the scatter of the next); then compound 2.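

In this assay, going by these compounds alone, the first exchange of one phenyl group for another on the saturated chain carbon bound to an oxygen on an aromatic ring gives a 1.9-fold higher number from compound 3 to compound 4 (0.27 log units; within the scatter), so 4-fluorophenyl and 2-methylphenyl are not separated at this position. The second ring-bearing group also falls between the two groups without a ring, with a 2.7-fold lower number from compound 2 to compound 4 (0.43 log units; beyond the scatter) and a 6.6-fold higher number from compound 1 to compound 4 (0.82 log units; beyond the scatter); among these four compounds, the two phenyl groups stay apart from both ethynyl and 2-methylprop-1-en-1-yl, and none goes against this. No accompanying measurement bears on the origin of these differences.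

The exchange from compound 3 to compound 4 changes both the substituent and its location on the phenyl ring, so 2-fluorophenyl and 4-methylphenyl would be needed to read those two changes apart. The compounds shown also leave open how unsubstituted phenyl, a longer saturated chain or a chain ending in an amine or a carboxylic acid would compare at this position.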